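A few compounds are considered here, and "the series" means these few. Any claim that something is new, unique, unknown or untested is made for them only; others in the source may bear on it.

Three compounds were measured in a functional assay on MDA-MB-231 cells (Homo sapiens) for inhibition, read by MTT assay, with a stated time of 72 h; on this read-out higher numbers stand for weaker inhibition and lower numbers for stronger inhibition: compound 1 `O=C(CSc1nc(Nc2ccccc2)c2ccccc2n1)Nc1ccccc1Br` at 14100 nM, compound 2 `O=C(CSc1nc(Nc2ccccc2)c2ccccc2n1)Nc1cccc(Cl)c1` at 16500 nM, and compound 3 `O=C(CSc1nc(Nc2ccccc2)c2ccccc2n1)Nc1cccc([N+](=O)[O-])c1` at 33000 nM.

Compound 3 holds the highest number of the three. Its nearest neighbour is compound 2, from which the step of a 2.0-fold higher number from compound 2 to compound 3 (0.30 log units; within the scatter) stays within the scatter, while the step of a 2.3-fold higher number from compound 1 to compound 3 (0.37 log units; beyond the scatter) is modest but lies beyond it.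

Compound 4 `O=C(CSc1nc(Nc2ccccc2)c2ccccc2n1)Nc1ccc(Cl)cc1` is not yet measured. It differs from compound 3 by 4-chlorophenyl in place of 3-nitrophenyl on an amide-type nitrogen. Among the measured compounds shown here, no measured step covers this exact exchange. The step of a 2.0-fold higher number from compound 2 to compound 3 (0.30 log units; within the scatter) concerns nitro against chloro on the ring, though with the chloro at a different printed position, and the step of a 1.2-fold higher number from compound 1 to compound 2 (0.07 log units; within the scatter) shows that two halogenated rings sat within the scatter of one another. On that basis a return to a chloro-bearing ring is expected to bring a somewhat lower number in this assay, roughly a 1.9-fold lower number from compound 3 to compound 4 (0.29 log units; within the scatter), though the change could also stay within the scatter. Compound 4 is therefore estimated at 17000 nM, with a range from 8000 nM to 36000 nM.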

Compound 4, half-maximal inhibitory concentration: 17200 nM
Beside the measured number, compound 4's estimate is 1.0-fold (0.01 log units) below it; low and high end bracket the measured number.
By their numbers in this assay, from the lowest: compounds 1, 2, 4 and 3 (each within the scatter of the next, the first and the last beyond it).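

In this assay the exchange of 3-chlorophenyl for 4-chlorophenyl on the amide-type nitrogen gives a 1.0-fold higher number from compound 2 to compound 4 (0.02 log units; within the scatter) and so, for these two compounds, the printed place of the chloro on this ring does not separate them beyond the scatter. The exchange of 2-bromophenyl for 4-chlorophenyl gives a 1.2-fold higher number from compound 1 to compound 4 (0.09 log units; within the scatter) and the exchange of 3-nitrophenyl for 4-chlorophenyl gives a 1.9-fold lower number from compound 3 to compound 4 (0.28 log units; within the scatter) so compound 3 now lies within the scatter of two chloro-bearing compounds, compound 2 and compound 4, and beyond it only from compound 1. Nothing available here accounts for these numbers.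

The compounds shown leave open whether 4-nitrophenyl would match 3-nitrophenyl at this nitrogen, which would separate the group from its place on the ring. They also leave open how an amine or a carboxylic acid on this ring would read in this assay here.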